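Swapping oxygen for sulfur on a shared core

This account rests on a few compounds, and the source may have more. Where it says the series, first, only, none or still open, it means among the compounds named here.

Measured compounds:
compound 1, `Nc1cc(N)c2nc(-c3ccccc3)c(Oc3ccc(Cl)c(Cl)c3)nc2c1`, 33900 nM
compound 2, `COc1ccc(CNc2nc3cc(N)cc(N)c3nc2-c2ccccc2)cc1`, 4070 nM

Of the compounds shown here, two have been tested in a functional assay on SR cells (Homo sapiens) for inhibition, read by sulforhodamine B assay, with a stated time of 48 h; on this read-out higher numbers stand for weaker inhibition of growth and lower numbers for stronger inhibition of growth. Compound 1 gives 33900 nM, which is the higher of the two numbers and therefore the weaker inhibition. Compound 2 gives 4070 nM, a clearly lower number that lies beyond the usual scatter; the two compounds differ in more than one place, so their gap cannot be attributed to any single change.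

Compound 3, `Nc1cc(N)c2nc(-c3ccccc3)c(Sc3ccc(Cl)c(Cl)c3)nc2c1`, has not yet been measured. It is compound 1 with one change: (3,4-dichlorophenyl)sulfanyl in place of 3,4-dichlorophenoxy on an aromatic carbon. The ring, its chlorine substituents and the count of heavy atoms all stay the same; only the linking atom differs. Among the compounds with values here, nothing among the measured compounds shows what such an exchange does in this assay , so the expectation rests on the small size of the change alone. Compound 3 is therefore expected to stay close to compound 1, with a step of a 1.4-fold lower number from compound 1 to compound 3 (0.13 log units; within the scatter) that need not exceed the scatter. The estimate for compound 3 in this assay is 25000 nM, within a range from 8000 nM to 80000 nM.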

Compound 3, concentration for 50% growth inhibition: 4680 nM
Estimate against measurement, compound 3: 5.3-fold (0.73 log units) above, outside the stated range (below it).
By their numbers in this assay, from the lowest: compounds 2 and 3 (each within the scatter of the next); then compound 1.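

In this assay, the linking atom on the aromatic carbon next to the ring nitrogen proves to matter: (3,4-dichlorophenyl)sulfanyl in place of 3,4-dichlorophenoxy gives a 7.2-fold lower number from compound 1 to compound 3 (0.86 log units; beyond the scatter). The phenyl ring, its chlorine substituents and the rest of the shared core stay the same, so this step belongs to the exchange of oxygen for sulfur alone, a link that compound 1 and compound 2, which differ in more than one place, could not reveal. What lies behind the step cannot be said, as no measurement accompanying these compounds bears on it.

The compounds shown leave open how other links at this position would behave, for example a methylene group or a sulfonyl group joining the same 3,4-dichlorophenyl ring to the core. They also leave open whether sulfur would give a step of similar size with a different group on the linking atom, such as a pyridine ring or a longer alkyl chain, since this single pair establishes no general rule.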